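Ester to Ethylamide on a Pyridine Sulfonamide Core

The source may hold more compounds than are shown below. What is called first, only, known or untested is meant among the compounds shown, and "the series" means these compounds.

Measured compounds:
- compound 1 `COc1cc(Cl)ccc1S(=O)(=O)Nc1cccnc1`: "not determined" (no result reported)
- compound 2 `COC(=O)c1cncc(NS(=O)(=O)c2cc(Cl)ccc2OC)c1`: > 20000 nM

In an assay on isolated protein for inhibition of alkaline phosphatase, tissue-nonspecific isozyme (Homo sapiens) (on this read-out lower numbers stand for stronger inhibition and higher numbers for weaker inhibition), compound 2 gives only a limit, > 20000 nM, not a number. Compound 1 has no result in this assay. Compound 3 `CCNC(=O)c1cncc(NS(=O)(=O)c2cc(Cl)ccc2OC)c1` differs from compound 2 in one place: ethylamino in place of methoxy on a carbonyl carbon. Within the data shown here, no measured step exists here, so the expected shift a step that the limit leaves unreadable from compound 2 to compound 3 for compound 3 is stated with little support, and no direction beyond the scatter is expected. Compound 3 is estimated at 30000 nM, within 8000 nM to 100000 nM, most likely again reported only as a limit.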

Compound 3, half-maximal inhibitory concentration: > 20000 nM
Compound 3: only a limit was reported; the forecaster's own chance of this, stated with the estimate: 75%; the middle value is on the limit's open side.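

Among these compounds, compound 2 and compound 3 each give only a limit, and no step between them can be read. The compounds shown leave open how strongly either inhibits the enzyme, and whether ethylamino in place of methoxy changes that.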